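This account rests on a few compounds, and the source may have more. Where it says the series, first, only, none or still open, it means among the compounds named here.

Results so far in an ADME assay on Vero cells (Chlorocebus sabaeus) for cytotoxicity; a higher number here means a weaker inhibitor, a lower number a stronger inhibitor

- compound 1 `Nc1ccn([C@@H]2S[C@H](CO)C=C2F)c(=O)n1` gives > 100000 nM
- compound 2 `Nc1ncnc2c1ncn2[C@@H]1S[C@H](CO)C=C1F` gives > 100000 nM
- compound 3 `O=c1[nH]cnc2c1ncn2[C@@H]1S[C@H](CO)C=C1F` gives > 100000 nM

Each of these readings is a limit of the assay and not a number (the limit of > 100000 nM in this assay, at which 3 of the 3 values shown sit). Compound 2 therefore has a limit and no exact value (> 100000 nM).

Compound 4 `Nc1nc(F)nc2c1ncn2[C@@H]1S[C@H](CO)C=C1F` carries fluoro in place of hydrogen on an aromatic carbon, between two ring nitrogen atoms (fluoro in place of hydrogen on an aromatic carbon). For the measured compounds named here, no measured pair shows what such a change does (this assay), so no step beyond the scatter is expected, in either direction. That expectation rests on the limit of compound 2 (> 100000 nM). The estimated step is correspondingly small (a number no higher from compound 2 to compound 4 (the limit leaves the size open)). For compound 4 the expected value is 100000 nM (estimated range 30000 nM to 300000 nM).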

Compound 4, half-maximal inhibitory concentration: 7600 nM
The estimate for compound 4 lay 13-fold (1.12 log units) above the measured number; measured number below the stated range.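

In this assay, this position is not neutral: fluoro in place of hydrogen on an aromatic carbon, between two ring nitrogen atoms, gives an at least 13-fold lower number from compound 2 to compound 4 (1.11 log units; beyond the scatter). A single added fluorine atom is therefore enough to bring a measurable effect on these cells. The full size of the step stays open, as compound 2 has only a limit of the assay: the limit of > 100000 nM in this assay, at which 3 of the 4 values shown sit.

The compounds shown leave open whether chloro, methyl or an amine at this position would lower the number as well. They also leave open whether fluoro would have the same effect on the core of compound 1.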